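The source may hold more compounds than are shown below. What is called first, only, known or untested is meant among the compounds shown, and "the series" means these compounds.

Measured so far in a functional assay with Oryctolagus cuniculus as the target; on this read-out higher numbers stand for weaker inhibition and lower numbers for stronger inhibition:
- compound 1 `CNC(=N)Nc1nc(-c2ccc(OC)cc2)c(-c2ccc(OC)cc2)s1` gives 62 nM
- compound 2 `C/N=C(/NC)Nc1nc(-c2ccc(OC)cc2)c(-c2ccc(OC)cc2)s1` gives 970 nM
- compound 3 `COc1ccc(-c2nc(/N=C(\N)n3ccnc3)sc2-c2ccc(OC)cc2)cc1` gives only a limit, > 100 nM

Compound 2 carries the highest of the two plain numbers in this assay; the nearest stands a 16-fold higher number from compound 1 to compound 2 (1.19 log units; beyond the scatter). For compound 3 the read-out is the limit of > 100 nM in this assay, at which 1 of the 3 values shown sits, so its distance from compound 2 cannot be read: a step that the limit leaves unreadable from compound 2 to compound 3.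

Compound 4 `CNC(=O)NCc1nc(-c2ccc(OC)cc2)c(-c2ccc(OC)cc2)s1` differs from compound 2 by a group of 6 heavy atoms (3 carbon, 2 nitrogen, 1 oxygen; no ring) in place of a group of 6 heavy atoms (3 carbon, 3 nitrogen; no ring), on an aromatic carbon. The group that leaves has no common name; the group that enters is ((methylcarbamoyl)amino)methyl, and the place is an aromatic carbon of the five-membered aromatic ring of the shared core, two ring bonds from two ring atoms that each bear a 4-methoxyphenyl group.

Of the measured steps, a 16-fold higher number from compound 1 to compound 2 (1.19 log units; beyond the scatter) is the only one that is both readable and sited at this same group; an at least 1.6-fold higher number from compound 1 to compound 3 (0.20 log units; that floor lies within the scatter) has a floor within the scatter. Going by the values given here, neither exchanges the leaving group for a urea-type chain, so no step of this kind has been measured. Compound 4 is therefore expected to sit near compound 2, at an estimated 1500 nM with a range of 300 nM to 8000 nM; the expected step is a 1.5-fold higher number from compound 2 to compound 4 (0.19 log units; within the scatter), within the scatter.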

Compound 4, half-maximal inhibitory concentration: 22 nM
Compound 4: the middle estimate sits 68-fold (1.83 log units) above what was measured; measured number below the stated range.
By their numbers in this assay, from the lowest: compound 4; then compound 1; then compound 2.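

In this assay, the ((methylcarbamoyl)amino)methyl group on this aromatic carbon gives a 44-fold lower number from compound 2 to compound 4 (1.64 log units; beyond the scatter). The group that leaves and the group that enters have the same counts of heavy atoms, hydrogen-bond donors and acceptors, so those counts do not account for the change, and this place responds strongly to the make-up of the chain. Compound 4 also improves on the smaller chain of compound 1, with a 2.8-fold lower number from compound 1 to compound 4 (0.45 log units; beyond the scatter), and its gain over compound 3 is only a floor, an at least 4.5-fold lower number from compound 3 to compound 4 (0.65 log units; beyond the scatter), since the value of compound 3 is a limit: the limit of > 100 nM in this assay, at which 1 of the 4 values shown sits.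

Compound 4 differs from compound 2 in both its carbonyl and the carbon that links the chain to the ring, and the compounds shown do not separate these two features, nor do they give any cause for the change. On these data alone, what a simple amine, a carboxylic acid or a longer chain would give at this place also stays open.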